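Series notes: amide aryl swap on the shared core

The source may report more compounds than this note shows. Statements on the series, on what has been measured and on what is new or still open speak of the compounds shown alone.

Within the data shown here, compound 1 `COc1ccc(NC(=O)CN2CCN(c3nnc(Cc4ccncc4)c4ccccc34)CC2)cc1OC` gives in a functional assay on MDA-MB-231 cells (Homo sapiens) for cytotoxicity, read by MTT assay, with a stated time of 72 h (a higher number here means a weaker inhibitor, a lower number a stronger inhibitor), a value of 100 nM, the lowest of the three numbers so far. Compound 2 `O=C(CN1CCN(c2nnc(Cc3ccccc3)c3ccccc23)CC1)Nc1ccc(F)c(C(F)(F)F)c1` gives 760 nM in this assay, and compound 3 `O=C(CN1CCN(c2nnc(Cc3ccccc3)c3ccccc23)CC1)Nc1cccc(F)c1` gives 3730 nM. Among the measured compounds shown here, the only single-point step measured is a 4.9-fold higher number from compound 2 to compound 3 (0.69 log units; beyond the scatter), a change of the aryl on the amide-type nitrogen between two fluorinated phenyls. Compound 1 and compound 2 differ in more than one place, so their two values are taken only as they stand.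

Compound 4 `O=C(CN1CCN(c2nnc(Cc3ccncc3)c3ccccc23)CC1)Nc1c(F)cccc1F` differs from compound 1 by 2,6-difluorophenyl in place of 3,4-dimethoxyphenyl on an amide-type nitrogen. The step from compound 2 to compound 3 bears on this change only loosely, since it also alters the aryl on the amide-type nitrogen, and it was modest. For the measured compounds named here, no measured step covers 3,4-dimethoxyphenyl against any fluorinated phenyl on an otherwise identical core. On this basis a higher number is expected for compound 4, with the step of a 6.0-fold higher number from compound 1 to compound 4 (0.78 log units; beyond the scatter) held to the size seen between fluorinated aryls. Compound 4 is therefore estimated at 600 nM, within a range of 150 nM to 2500 nM.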

Compound 4, half-maximal inhibitory concentration: 1900 nM
Compound 4: the middle estimate sits 3.2-fold (0.50 log units) below what was measured; low and high end bracket the measured number.
By their numbers in this assay, from the lowest: compound 1; then compound 2; then compounds 4 and 3 (each within the scatter of the next).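

On the core of compound 1, the aryl on the amide-type nitrogen is now shown to matter in its own right: in this assay, 2,6-difluorophenyl in place of 3,4-dimethoxyphenyl gives a 19-fold higher number from compound 1 to compound 4 (1.28 log units; beyond the scatter), a large step. Among these compounds, this is the first direct comparison of 3,4-dimethoxyphenyl with a fluorinated phenyl on an otherwise identical core, whereas the earlier single-point step, a 4.9-fold higher number from compound 2 to compound 3 (0.69 log units; beyond the scatter), stayed among fluorinated aryls on a different core. Nothing at hand accounts for the size of this step.

As far as these compounds go, it remains open whether the step follows the loss of the methoxy groups or the arrival of the fluorines, which an unsubstituted phenyl or a single methoxy on the same core could help separate. Also open, from the compounds shown here alone, are how 3,4-dimethoxyphenyl behaves on the core of compound 2 and how a dimethylamino group or a carboxylic acid on this phenyl would read.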